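The source may hold more compounds than are shown below. What is called first, only, known or untested is meant among the compounds shown, and "the series" means these compounds.

Measured compounds:
- Compound 1 `CC1=CC[C@H](C(C)(C)NC(=S)NN)CC1`: 46700 nM
- Compound 2 `CC1=CC[C@H](C(C)(C)NC(=S)N/N=C/c2ccc(O)cc2)CC1`: > 100000 nM
- Compound 3 `CC1=CC[C@H](C(C)(C)NC(=S)N/N=C/c2ccc(Cl)cc2)CC1`: > 100000 nM

In a functional assay on MCF7 cells (Homo sapiens) for inhibition, read by sulforhodamine B assay, with a stated time of 48 h (on this read-out lower numbers stand for stronger inhibition of growth and higher numbers for weaker inhibition of growth), compound 1 gives 46700 nM. Compound 2 reaches only a limit of the assay, > 100000 nM. Compound 3 likewise reaches only a limit of the assay, > 100000 nM. For the measured compounds named here, the sole step between measured neighbours, a step that the two limits leave unreadable from compound 2 to compound 3, therefore cannot be read, since both ends sit at the limit of > 100000 nM in this assay, at which 2 of the 3 values shown sit. Where compound 3 stands is thus known only as a limit: weaker inhibition of growth than the assay resolves.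

Compound 4 `CC1=CC[C@H](C(C)(C)NC(=S)N/N=C/c2ccc[nH]2)CC1` is not yet measured. It differs from compound 3 by 1H-pyrrol-2-yl in place of 4-chlorophenyl on a carbon with a double bond to nitrogen. Going by the values given here, no measured step touches this change: the one step that varies the aromatic group, from compound 2 to compound 3, is unreadable, and compound 1 carries no aromatic group at all. Among the compounds with values here, the only guidance is that both aromatic hydrazones measured so far sit at the limit of > 100000 nM in this assay, at which 2 of the 3 values shown sit, whereas compound 1 alone gives a number. On that basis compound 4 is expected to remain near the limit, and the step that the limit leaves unreadable from compound 3 to compound 4 is estimated as none beyond the scatter. Compound 4 is therefore estimated at 120000 nM in this assay, within 40000 nM to 350000 nM.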

Compound 4, concentration for total growth inhibition: 11500 nM
For compound 4 the middle estimate is 10-fold (1.02 log units) above the measured one; the measured number lies below the stated range.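

In this assay, the group on the carbon with a double bond to nitrogen proves able to decide whether a number can be read at all: 1H-pyrrol-2-yl in place of 4-chlorophenyl gives an at least 8.6-fold lower number from compound 3 to compound 4 (0.93 log units; beyond the scatter), and 1H-pyrrol-2-yl in place of 4-hydroxyphenyl gives an at least 8.6-fold lower number from compound 2 to compound 4 (0.93 log units; beyond the scatter). An aromatic group at this carbon therefore does not in itself cost growth inhibition, as the two phenyl compounds alone had suggested, and the comparison with the compound that carries no aromatic group gives a 4.1-fold lower number from compound 1 to compound 4 (0.61 log units; beyond the scatter). Compound 2 and compound 3 remain at a limit of the assay, so no step between them can be read: the limit of > 100000 nM in this assay, at which 2 of the 4 values shown sit.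

As far as these compounds go, what stays open is whether the result follows the hydrogen on the ring nitrogen of 1H-pyrrol-2-yl or the five-membered ring as such, a question that a furan or thiophene ring on the same carbon would address. From the compounds shown here alone, whether the limit belongs to six-membered aromatic rings in general also remains open, and a plain phenyl or a pyridine ring would test that.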